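The source may hold more compounds than are shown below. What is called first, only, known or untested is meant among the compounds shown, and "the series" means these compounds.

Of the compounds shown here, three of one shared core have been measured in a functional assay on M21 cells (Homo sapiens) for cytotoxicity, read by sulforhodamine B assay, with a stated time of 48 h; a lower number here means a stronger inhibitor, a higher number a weaker inhibitor. Compound 1 `Cc1ccccc1OS(=O)(=O)c1cccc(NC(=O)NCCCCl)c1` gives 29000 nM, compound 2 `Cc1ccccc1NS(=O)(=O)c1cccc(NC(=O)NCCCCl)c1` gives 60000 nM, and compound 3 `CCNC(=O)Nc1cccc(S(=O)(=O)Oc2ccccc2C)c1` gives 51000 nM. Compound 3 lies within the scatter of both neighbours: the step of a 1.8-fold higher number from compound 1 to compound 3 (0.25 log units; within the scatter) is small, and its value sits close to that of compound 2. Going by the values given here, the one step that reaches beyond the scatter, a 2.1-fold higher number from compound 1 to compound 2 (0.32 log units; beyond the scatter), concerns the group on the sulfonyl sulfur, not the aryl methyl. Compound 4 `CCCc1ccccc1OS(=O)(=O)c1cccc(NC(=O)NCC)c1` differs from compound 3 by ethyl in place of hydrogen on a saturated chain carbon bound to an aromatic carbon. Among the compounds with values here, no measured step touches that position, so no change beyond the scatter is expected in this assay. For compound 4 the estimate is 51000 nM, with a range from 25000 nM to 105000 nM, an expected step of no change at the digits printed from compound 3 to compound 4 (within the scatter).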

Compound 4, half-maximal inhibitory concentration: 25000 nM
Compound 4: middle estimate off by 2.0-fold (0.31 log units), on the high side; the measured number falls inside the stated range.
By their numbers in this assay, from the lowest: compounds 4, 1, 3 and 2 (each within the scatter of the next, the first and the last beyond it).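

Going by these compounds alone, the change from methyl to propyl gives a 2.0-fold lower number from compound 3 to compound 4 (0.31 log units; beyond the scatter) in this assay and shows that this position, untouched by the earlier steps, can affect the result. The longer chain is accepted here, and the number moves towards a stronger inhibitor, though only modestly. Nothing available explains why the number moved.

As far as these compounds go, whether a longer chain such as butyl would lower the number further remains open. So does the effect of placing an amine or a carboxylic acid at this position.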